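The source may report more compounds than this note shows. Statements on the series, on what has been measured and on what is new or still open speak of the compounds shown alone.

Compound 1 `CC(C)CNC(=O)n1c(=O)oc2cc(C3CCN(C)CC3)ccc21` has the highest of the three numbers in an ADME assay on a cell-free system (plasma, Mus musculus) for metabolic stability, read by LC-MS, tested at 2 uM (a higher number here means that the compound lasts longer, a lower number that the compound disappears faster), where compound 1 gives 1.33 h. Compound 2 `CC(C)CNC(=O)n1c(=O)oc2cc(C3CCCCN3C)ccc21` gives 0.5 h and compound 3 `CC(C)CNC(=O)n1c(=O)oc2cc(C3CCCN(C)C3)ccc21` gives 0.833 h. The measured steps are a 2.7-fold lower number from compound 1 to compound 2 (0.42 log units; beyond the scatter), a 1.6-fold lower number from compound 1 to compound 3 (0.20 log units; within the scatter) and a 1.7-fold higher number from compound 2 to compound 3 (0.22 log units; within the scatter), and each of them swaps the 1-methylpiperidinyl group on an aromatic carbon. Compound 4 `CCCCCNC(=O)n1c(=O)oc2cc(C3CCN(C)CC3)ccc21` differs from compound 1 in a different part of the molecule: butyl in place of isopropyl on a saturated chain carbon bound to an amide-type nitrogen. Among the measured compounds shown here, none of the measured steps changes that chain, so they offer no direct guide, and no step beyond the scatter is expected. The estimate for compound 4 in this assay is therefore 1.1 h, between 0.5 h and 2.4 h, an expected 1.2-fold lower number from compound 1 to compound 4 (0.08 log units; within the scatter).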

Compound 4, half-life: 1.25 h
Compound 4: middle estimate off by 1.1-fold (0.06 log units), on the low side, within the range that was stated.
By their numbers in this assay, from the lowest: compounds 2, 3, 4 and 1 (each within the scatter of the next, the first and the last beyond it).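

With butyl in place of isopropyl on a saturated chain carbon bound to an amide-type nitrogen, the result is a 1.1-fold lower number from compound 1 to compound 4 (0.03 log units; within the scatter) in this assay and so stays within the scatter. Among the compounds shown here, this gives the first measured step in this part of the molecule, as all the earlier steps swapped the 1-methylpiperidinyl group. No available measurement gives a reason for this result. Going by these compounds, whether a cyclohexyl group or a chain carrying a carboxylic acid would also stay within the scatter remains open. So does whether butyl would give the same result alongside 1-methylpiperidin-2-yl or 1-methylpiperidin-3-yl.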